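This account rests on a few compounds, and the source may have more. Where it says the series, first, only, none or still open, it means among the compounds named here.

Measured so far in an ADME assay on HEL cells (Homo sapiens) for cytotoxicity; a higher number here means that more compound is tolerated, a lower number that less compound is tolerated:
- compound 1, `Cc1cccc(OCCCCCn2ccc(=O)[nH]c2=O)c1`: > 100000 nM
- compound 2, `CC(C)c1ccc(OCCCCCn2ccc(=O)[nH]c2=O)cc1`: > 100000 nM

Both values are limits of the assay, not numbers. Compound 1 reaches only the limit > 100000 nM in this assay. Compound 2 likewise stops at the limit > 100000 nM in this assay. So compound 2 stands at the limit of > 100000 nM in this assay, at which 2 of the 2 values shown sit, and nothing on the shared core separates the two values: no step between measured compounds can be drawn, and the two entries say only that neither compound shows cytotoxicity within the range covered.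

The next compound, compound 3, `N#Cc1ccc(OCCCCCn2ccc(=O)[nH]c2=O)cc1`, differs from compound 2 as follows: cyano in place of isopropyl on an aromatic carbon.

With the two measured values both at the limit, no size or direction of step in this assay is expected beyond the scatter; the working assumption is that the reading for compound 3 again ends at the limit. Compound 3 is therefore expected to give 100000 nM in this assay, within 30000 nM to 300000 nM, because compound 2 already sits at the limit of > 100000 nM in this assay, at which 2 of the 2 values shown sit. The expected step from compound 2 to compound 3 is a number no higher from compound 2 to compound 3 (the limit leaves the size open), that is, none beyond the scatter.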

Compound 3, half-maximal cytotoxic concentration: 100000 nM
Compound 3: the middle estimate sits on the measured number at the digits printed; the measured number falls inside the stated range.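

In this assay compound 3, with cyano in place of isopropyl on an aromatic carbon para to a large group, gives 100000 nM, the first entry in the series that is a number and not a limit. Compound 2 gives > 100000 nM, which is a limit of the assay. The change at this position therefore reads only as a number no higher from compound 2 to compound 3 (the limit leaves the size open), its size cannot be read, and the new number shows that cyano at this position still leaves the reading at the same figure as the limit, with no lower value yet on the shared core.

The compounds shown leave open how far the reading of compound 2 lies past its limit, and so whether swapping isopropyl for cyano changes the tolerated concentration at all. They also leave open whether an amine or a carboxylic acid on the same aromatic carbon, or a longer chain, would bring this assay to a clearly lower number.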